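Removing the chloro group from compound 2

The compounds below may be only part of what the source reports. "The series", "measured", "known", "first", "only" and "open" are said of these compounds alone.

In a functional assay on HCC827 cells (Homo sapiens) for inhibition, read by fluorescence, with a stated time of 72 h (a lower number here means a stronger inhibitor of growth, a higher number a weaker inhibitor of growth), compound 2 `CC(C)CCn1cnc2c(Nc3cccc(Cl)c3)nc(N[C@H]3CC[C@H](N)CC3)nc21` reads 10300 nM while compound 1 `CC(C)CCn1cnc2c(NCc3cccc(Cl)c3)nc(N[C@H]3CC[C@H](N)CC3)nc21` reads 16700 nM and the two lie within the scatter of each other. Compound 3 `CC(C)CCn1cnc2c(Nc3ccccc3)nc(N[C@H]3CC[C@H](N)CC3)nc21` brings the change hydrogen in place of chloro on an aromatic carbon in which hydrogen stands in place of chloro on an aromatic carbon. Among the compounds with values here, the single measured step of a 1.6-fold lower number from compound 1 to compound 2 (0.21 log units; within the scatter) keeps the chloro group and so says little about losing it. No step beyond the scatter is therefore expected in this assay and the estimated move a 1.2-fold higher number from compound 2 to compound 3 (0.07 log units; within the scatter) stays small. Compound 3 is expected at 12000 nM within an estimated range of 5000 nM to 30000 nM in this measurement.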

Compound 3, concentration for 50% growth inhibition: 21700 nM
For compound 3 the middle estimate is 1.8-fold (0.26 log units) below the measured one; the range from low to high includes it.
By their numbers in this assay, from the lowest: compounds 2, 1 and 3 (each within the scatter of the next, the first and the last beyond it).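

In this assay, the chloro group on the six-membered aromatic ring is the first single change shown to move the number beyond the scatter, though only modestly (a 2.1-fold higher number from compound 2 to compound 3 (0.32 log units; beyond the scatter)). Replacing 3-chlorobenzyl with phenyl, by contrast, stays within the scatter (a 1.3-fold higher number from compound 1 to compound 3 (0.11 log units; within the scatter)). No evidence here explains why the chloro group makes this difference. Going by these compounds, whether fluoro, bromo, methyl or an amine at this same place would match chloro remains open. So does whether hydrogen in place of chloro on the 3-chlorobenzyl group would bring a similar step.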